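Swapping a fluorinated benzyl ether for a phenethyl ether

The source may report more compounds than this note shows. Statements on the series, on what has been measured and on what is new or still open speak of the compounds shown alone.

Compound 1 `CCC1(Cc2ccccc2)OS(=O)(=O)C=C1OCc1ccc(F)cc1` and compound 2 `CC(C)C1(Cc2ccccc2)OS(=O)(=O)C=C1OCc1ccccc1` share a core and were both tested in an ADME assay on HEL cells (Homo sapiens) for cytotoxicity, with a stated time of 3 days; on this read-out higher numbers stand for lower toxicity in this test and lower numbers for higher toxicity in this test. For compound 1 the result is only a limit, >= 50000 nM. For compound 2 the result is likewise a limit, >= 80000 nM. Compound 1 thus stands at the limit of >= 50000 nM in this assay, at which 1 of the 2 values shown sits, with no plain number to compare against, and the other value shown is also a limit. Compound 3 `CCC1(Cc2ccccc2)OS(=O)(=O)C=C1OCCc1ccccc1` has not yet been measured in this assay. Its change from compound 1 is benzyl in place of 4-fluorophenyl on a saturated chain carbon bound to an oxygen on an unsaturated carbon. Among the compounds with values here, with no measured step to lean on, the step of a number no higher from compound 1 to compound 3 (the limit leaves the size open) is expected to be none beyond the scatter. Compound 3 is therefore expected to give 50000 nM, within 20000 nM to 100000 nM, most likely again reported as a limit.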

Compound 3, minimum cytotoxic concentration: >= 20000 nM
Compound 3 ended at the assay's limit (the forecaster's own chance of this, stated with the estimate: 80%); the middle value is on the limit's open side.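

Compound 1 and compound 3 both carry only limits in this assay, and the step between them cannot be read. Whether changing 4-fluorobenzyl to phenethyl alters cytotoxicity at all, and at what concentration any compound shown harms these cells, stays open.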